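Shortening the hydroxyalkyl chain of compound 1

A few compounds are considered here, and "the series" means these few. Any claim that something is new, unique, unknown or untested is made for them only; others in the source may bear on it.

Among the measured compounds shown here, compound 1 `COc1cc(NC(C)CCCNC(=O)NNC(=O)NCCCCCO)c2ncccc2c1` records 168000 nM in a functional assay on MIA PaCa-2 cells (Homo sapiens) for inhibition, read by MTT assay, with a stated time of 4 days (a lower number here means a stronger inhibitor, a higher number a weaker inhibitor), and is the weakest of the three compounds measured so far, with both gaps beyond the usual scatter of repeated measurements. Compound 3 `O=C1NCCN1C(c1ccccc1)(c1ccccc1)c1ccccc1` stands nearest to it at 31000 nM and compound 2 `COc1ccc(C(=NNC(=O)NNC(=O)NCCCC(C)Nc2cc(OC)cc3cccnc23)c2ccc(OC)cc2)cc1` furthest from it at 11000 nM on the stronger side. Neither compound 2 nor compound 3 differs from compound 1 in one place only, so the series offers no measured single change as a guide.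

The next compound to be tested is compound 4 `COc1cc(NC(C)CCCNC(=O)NNC(=O)NCCCO)c2ncccc2c1`, which keeps the core of compound 1 while its 5-hydroxypentyl group becomes 3-hydroxypropyl. The counted difference is hydroxy in place of 2-hydroxyethyl on a saturated chain carbon, three bonds along the chain from an amide-type nitrogen and it amounts to hydroxy in place of 2-hydroxyethyl on a saturated chain carbon, three bonds along the chain from an amide-type nitrogen.

For the measured compounds named here, with no measured step to lean on, the expectation in this assay is of no step beyond the scatter, in either direction. The estimated step is a 1.1-fold higher number from compound 1 to compound 4 (0.03 log units; within the scatter) and the range around it is kept wide. In this assay compound 4 is therefore expected at 180000 nM with 70000 nM to 450000 nM as its estimated range.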

Compound 4, half-maximal inhibitory concentration: >= 250000 nM
Compound 4: only a limit was reported (the forecaster's own chance of this, stated with the estimate: 15%); at least 1.3-fold (0.14 log units) between middle value and limit.
By their numbers in this assay, from the lowest: compound 2; then compound 3; then compound 1. At a limit, above all of these: compound 4.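

Compound 4 carries only a limit, not a number, in this assay: the limit of >= 250000 nM in this assay, at which 1 of the 4 values shown sits. Even so, this is the first change in the series that can be read at a single place, and replacing the 5-hydroxypentyl group with 3-hydroxypropyl gives an at least 1.4-fold higher number from compound 1 to compound 4 (0.17 log units; that floor lies within the scatter). The step shows no gain in strength from shortening this hydroxyalkyl chain on the core of compound 1, although its floor does not establish a real loss, and the terminal hydroxy group alone does not bring this shorter chain to a lower number.

From the compounds shown here alone, the true value of compound 4 stays open, so the two chain lengths give no measured size for the effect of shortening and no trend along the chain. Also open, going by these compounds, is whether a longer chain ending in hydroxy, or a chain of similar length ending in an amine or a carboxylic acid in place of the hydroxy, would take the number below that of compound 1 at 168000 nM.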